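Swapping one ring on compound 2

The compounds below may be only part of what the source reports. "The series", "measured", "known", "first", "only" and "open" are said of these compounds alone.

- compound 1 `Fc1ccc(Nc2cc3[nH]c(Nc4ccc(N5CCN(CC6CC6)CC5)cn4)nc3cn2)cc1F` gives 9%
- compound 2 `C[C@@H]1CN(c2ccc(Nc3nc4cnc(Nc5ccc(F)c(F)c5)cc4[nH]3)nc2)C[C@H](C)N1` gives 66%

These numbers come from an ADME assay on microsomes from liver (Rattus norvegicus) for metabolic stability, read by LC-MS, using NADPH, with a stated time of 60 min, tested at 0.1 uM (a lower number here means that less of the compound is left, a higher number that more of the compound is left), and compound 2 holds the higher of the two. The next molecule, compound 3 `Fc1ccc(Nc2cc3[nH]c(Nc4ccc(C5CCNCC5)cn4)nc3cn2)cc1F`, carries piperidin-4-yl in place of 3,5-dimethylpiperazin-1-yl on an aromatic carbon. Among the compounds with values here, only one measured step touches this same place: a number 57 percentage points higher from compound 1 to compound 2 (beyond the scatter). It is large and beyond the scatter, so the group at this place can matter greatly in this assay, but that step says nothing direct about piperidin-4-yl. Both groups are six-membered non-aromatic rings, so a modest fall is the cautious guess, though the direction is uncertain. The expected change is a number 11 percentage points lower from compound 2 to compound 3 (beyond the scatter) in this estimate. For compound 3 the estimated value is 55%, with an expected range from 30% to 80% here.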

Compound 3, percent of the compound remaining: 97%
The estimate for compound 3 lay 42 percentage points below the measured number; the whole stated range lies below it.
By their numbers in this assay, from the lowest: compound 1; then compound 2; then compound 3.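

The position still had room for improvement after compound 2: in this assay, piperidin-4-yl gives a number 31 percentage points higher from compound 2 to compound 3 (beyond the scatter) and so exceeds 3,5-dimethylpiperazin-1-yl, which had been the better of the two earlier groups. Measured against the 4-(cyclopropylmethyl)piperazin-1-yl group, the same ring gives a number 88 percentage points higher from compound 1 to compound 3 (beyond the scatter) in a single change at this place, and this swap also removes one ring hetero atom and both defined stereocentres of compound 2. No measurement shown here explains this gain.

Which of these differences matters remains open, since they arrive together in compound 3. A plain piperazin-1-yl ring, or a piperidin-4-yl ring with cyclopropylmethyl on its nitrogen, would help separate the effect of the ring from that of its substituents.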